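The source may hold more compounds than are shown below. What is called first, only, known or untested is meant among the compounds shown, and "the series" means these compounds.

In a functional assay on HT cells (Homo sapiens) for antiproliferative activity, read by fluorescence, with a stated time of 72 h (on this read-out higher numbers stand for weaker inhibition of growth and lower numbers for stronger inhibition of growth), three compounds with a shared core have been measured:

- compound 1 `CC(C)c1n[nH]c2c(NCc3ccc(-c4ccccn4)cc3)nc(SC(C)C(C)O)nc12`: 190 nM
- compound 2 `CC(C)c1n[nH]c2c(NCc3ccc(-c4ccccn4)cc3)nc(SC3CCCCC3O)nc12`: 636 nM
- compound 3 `CNCCSc1nc(NCc2ccc(-c3ccccn3)cc2)c2[nH]nc(C(C)C)c2n1`: 56 nM

The three differ only in the group on the sulfur. Compound 3, which carries 2-(methylamino)ethyl there, has the lowest number of the three. Its two steps are a 3.4-fold lower number from compound 1 to compound 3 (0.53 log units; beyond the scatter) and an 11-fold lower number from compound 2 to compound 3 (1.06 log units; beyond the scatter), and both lie beyond the scatter.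

Compound 4 `CSCCSc1nc(NCc2ccc(-c3ccccn3)cc2)c2[nH]nc(C(C)C)c2n1` keeps the chain of compound 3 and alters its end: methylsulfanyl in place of methylamino on a saturated chain carbon, two bonds along the chain from a sulfur. In words, methylsulfanyl stands in place of methylamino on a saturated chain carbon, two bonds along the chain from a sulfur. Among the compounds with values here, no measured compound carries methylsulfanyl, so no step measures this change directly. Within the data shown here, the only comparison without methylamino comes from compound 1 and compound 2, and both of these also differ from compound 3 in the chain itself. The large step to compound 2 therefore seems a poor guide, and the modest step to compound 1 a better one.

A modest move towards a higher number is expected, resting on compound 1 at 190 nM. The expected change is a 2.3-fold higher number from compound 3 to compound 4 (0.37 log units; beyond the scatter). For compound 4 the estimated value is 130 nM, with an expected range from 45 nM to 380 nM.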

Compound 4, concentration for 50% growth inhibition: 975 nM
Estimate against measurement, compound 4: 7.5-fold (0.88 log units) below, outside the stated range (above it).
By their numbers in this assay, from the lowest: compound 3; then compound 1; then compounds 2 and 4 (each within the scatter of the next).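

In this assay, the end of the chain on the sulfur proves to matter on its own: with the chain held and only methylamino exchanged for methylsulfanyl, the result is a 17-fold higher number from compound 3 to compound 4 (1.24 log units; beyond the scatter) and the largest step among these four compounds. The earlier steps shown here all replaced the whole group on the sulfur, so they could not separate the chain from its end, whereas this change keeps the count of 2 heavy atoms and goes from 1 hydrogen-bond donor to 0. Compared across whole groups, 2-(methylsulfanyl)ethyl also falls behind 2-hydroxy-1-methylpropyl, with a 5.1-fold higher number from compound 1 to compound 4 (0.71 log units; beyond the scatter) and beyond the scatter, while the comparison with 2-hydroxycyclohexyl gives a 1.5-fold higher number from compound 2 to compound 4 (0.19 log units; within the scatter) and so does not separate those two groups.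

Nothing available here accounts for the size of the step at the chain end. From the compounds shown here alone, it remains open whether a primary amine, a dimethylamino group or a hydroxyl at the same chain end would stay close to compound 3, and whether a longer chain carrying the methylamino group would keep its number.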